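Ethoxy substitution on the anilino ring of compound 2

The source may hold more compounds than are shown below. What is called first, only, known or untested is meant among the compounds shown, and "the series" means these compounds.

Two compounds of the series carry the same core with the trifluoromethylbenzylthio group and differ only in the amine substituent. Compound 1, `CCCCCCCCCCCCNc1nc(SCc2ccc(C(F)(F)F)cc2)nc2ccccc12`, bears a dodecylamino chain. In a functional assay on MCF7 cells (Homo sapiens) for cytotoxicity, read by MTT assay, with a stated time of 72 h (a higher number here means a weaker inhibitor, a lower number a stronger inhibitor), compound 1 gives only a limit, > 50000 nM. Compound 2, `FC(F)(F)c1ccc(CSc2nc(Nc3ccccc3)c3ccccc3n2)cc1`, bears an anilino group instead. In this assay, among the compounds with values here, compound 2 gives 44000 nM, the only number in this set; the rest is covered by the limit of > 50000 nM in this assay, at which 1 of the 2 values shown sits.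

Compound 3, `CCOc1ccccc1Nc1nc(SCc2ccc(C(F)(F)F)cc2)nc2ccccc12`, differs from compound 2 by ethoxy in place of hydrogen on an aromatic carbon, placed on the ring of the anilino group, ortho to a large group. Within the data shown here, no pair of measured compounds shows this change, so the size of the step in this assay cannot be read from the data. Because compound 2 gives 44000 nM, little room is left for a weaker reading to be recorded as a number; the step from compound 2 to compound 3 is expected to be small, within the scatter or slightly toward weaker inhibition, a 1.0-fold higher number from compound 2 to compound 3 (0.01 log units; within the scatter). Compound 3 is therefore estimated at 45000 nM, with a range from 15000 nM to 120000 nM, and a fair chance that only a limit is reported.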

Compound 3, half-maximal inhibitory concentration: > 50000 nM
Compound 3 gave a limit, no number (the forecaster's own chance of this, stated with the estimate: 40%); at least 1.1-fold (0.04 log units) between middle value and limit.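

Placing ethoxy in place of hydrogen on an aromatic carbon of the anilino ring, ortho to a large group, gives the first reading of this change in the series: in this assay, the result is an at least 1.1-fold higher number from compound 2 to compound 3 (0.05 log units; that floor lies within the scatter). Compound 3 gives only a limit, > 50000 nM, so the 2-ethoxyphenyl group does not bring this position to a numbered reading, and the printed floor of the step does not establish a real loss relative to the unsubstituted anilino group. With this result, the numbered reading of compound 2 remains the only one in the set, and the change adds a further compound to those at the upper limit: the limit of > 50000 nM in this assay, at which 2 of the 3 values shown sit.

On these data alone, the true size of the step remains open, as the limit gives only its floor and leaves no way to tell a slight change from a large one. As far as these compounds go, whether a hydroxyl group, a fluorine atom, an amine or a carboxylic acid on the same ring would give a stronger reading in this assay also remains open.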